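From compound 3 to compound 4: a longer ester chain

The source may report more compounds than this note shows. Statements on the series, on what has been measured and on what is new or still open speak of the compounds shown alone.

Measured in a functional assay (strain AB) with Danio rerio as the target, read by microscopy, with a stated time of 1 h; on this read-out higher numbers stand for an effect only at larger amounts of compound and lower numbers for an effect already at smaller amounts:
Compound 1 `CCN1CCc2c(sc(NC(=O)Nc3cccc(Cl)c3Cl)c2C(N)=O)C1` gives 17400 nM
Compound 2 `CCN1CCc2c(sc(NC(=S)Nc3ccc(Cl)cc3)c2C(N)=O)C1` gives 6570 nM
Compound 3 `CC(C)(C)OC(=O)CCC[N+]1(C)CCc2c(sc(NC(=O)Nc3ccc(Cl)cc3)c2C(N)=O)C1` gives 250 nM

Of these three, compound 3 has the lowest number, and compound 2 and compound 1 both lie higher, beyond the scatter. Compound 4 `CC(C)(C)OC(=O)CCCCC[N+]1(C)CCc2c(sc(NC(=O)Nc3ccc(Cl)cc3)c2C(N)=O)C1` differs from compound 3 only in its ester chain: 2-(tert-butoxycarbonyl)ethyl in place of tert-butoxycarbonyl on a saturated chain carbon, three bonds along the chain from an amine nitrogen in a ring. In words, 2-(tert-butoxycarbonyl)ethyl stands in place of tert-butoxycarbonyl on a saturated chain carbon, three bonds along the chain from an amine nitrogen in a ring. For the measured compounds named here, no measured pair shows what altering this chain does. The expectation therefore starts from compound 3 (250 nM) and foresees no change beyond the scatter in this assay. The estimated step is a 1.2-fold higher number from compound 3 to compound 4 (0.08 log units; within the scatter) and carries wide uncertainty. For compound 4, the expected value is 300 nM, with an estimated range of 70 nM to 1300 nM.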

Compound 4, half-maximal effective concentration: 110 nM
Compound 4: middle estimate off by 2.7-fold (0.44 log units), on the high side, and the stated range covers the measured number.
By their numbers in this assay, from the lowest: compound 4; then compound 3; then compound 2; then compound 1.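

In this assay, the longer ester chain gives a 2.3-fold lower number from compound 3 to compound 4 (0.36 log units; beyond the scatter), the only pair shown that differs in one place. This shows that the number responds to chain length at this position: 2-(tert-butoxycarbonyl)ethyl in place of tert-butoxycarbonyl lowers it modestly, and the change does not lose the effect. Nothing available explains this step.

With a single step, no trend in chain length is established. On these data alone, it remains open whether a still longer chain would lower the number further, or how a free carboxylic acid in place of the tert-butyl ester would read.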